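Anilino nitrogen variation: compound 2 to compound 3

The source may hold more compounds than are shown below. What is called first, only, known or untested is meant among the compounds shown, and "the series" means these compounds.

Measured so far:
compound 1, `CNc1cccc(-c2cc(=O)c3cc(N4CCCC4)ccc3[nH]2)c1`, gives 35 nM in a functional assay on NCI-H460 cells (Homo sapiens) for cytotoxicity; a higher number here means a weaker inhibitor, a lower number a stronger inhibitor.
compound 2, `CCNc1cccc(-c2cc(=O)c3cc(N4CCCC4)ccc3[nH]2)c1`, gives 20 nM in this assay.

Compound 2 and compound 1 lie within the scatter of each other; the only step shown, a 1.8-fold lower number from compound 1 to compound 2 (0.24 log units; within the scatter), comes from a methyl in place of hydrogen on the saturated chain carbon bound to the aniline nitrogen.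

The next compound is compound 3, `CN(C)c1cccc(-c2cc(=O)c3cc(N4CCCC4)ccc3[nH]2)c1`. It differs from compound 2 by dimethylamino in place of ethylamino on an aromatic carbon; the two have the same atoms, joined differently. The ethylamino that leaves carries one hydrogen-bond donor and one acceptor; the dimethylamino that enters carries no donor and one acceptor. The place is an aromatic carbon of a six-membered aromatic ring of carbon only, meta to a large group.

Going by the values given here, only the step from compound 1 to compound 2 bears on this, and it was within the scatter. Among the compounds with values here, it tests adding a carbon to the chain, not removing the donor; no measured step tests that. The expected step of a 1.5-fold higher number from compound 2 to compound 3 (0.18 log units; within the scatter) in this assay is therefore small, with the direction uncertain. Compound 3 is estimated at 30 nM, within 10 nM to 90 nM.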

Compound 3, half-maximal inhibitory concentration: 13 nM
The estimate for compound 3 lay 2.3-fold (0.36 log units) above the measured number; the measured number falls inside the stated range.
By their numbers in this assay, from the lowest: compounds 3, 2 and 1 (each within the scatter of the next, the first and the last beyond it).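

In this assay the dimethylamino group, which carries no hydrogen-bond donor, gives the first measured test of losing the donor at this aromatic carbon, and the swap between these two isomers gives a 1.5-fold lower number from compound 2 to compound 3 (0.19 log units; within the scatter) within the series. The clearer reading is a 2.7-fold lower number from compound 1 to compound 3 (0.43 log units; beyond the scatter) for methyl in place of hydrogen on the nitrogen on the aromatic ring, so among these three compounds the hydrogen on that nitrogen is not required for activity in this assay and the fully substituted nitrogen is accepted. No supporting data bear on the reason for this result.

From the compounds shown here alone, how diethylamino, a ring amine such as pyrrolidin-1-yl, or a primary amino group would compare at this aromatic carbon remains open. Whether the step from the methylamino to the dimethylamino compound follows the lost donor or the added carbon also stays unresolved, since the two changes travel together in that pair, and compound 2, which keeps the donor with the same atoms as compound 3, lies within the scatter of it.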